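Replacing the side group of compound 3

The compounds below may be only part of what the source reports. "The series", "measured", "known", "first", "only" and "open" are said of these compounds alone.

Compound 1 `CC(C)C(Nc1nnc[nH]1)c1ccc(-c2ccc3cccc(F)c3c2)[nH]c1=O` gives 17200 nM
Compound 2 `CC(C)C(c1ncc[nH]1)c1ccc(-c2ccc3cccc(F)c3c2)[nH]c1=O` gives 20600 nM
Compound 3 `CC(C)C(Cc1nnn[nH]1)c1ccc(-c2ccc3cccc(F)c3c2)[nH]c1=O` gives 27300 nM

All three values come from a physicochemical assay for solubility, in phosphate buffer, measured as kinetic solubility (a higher number here means a more soluble compound, a lower number a less soluble compound), and they lie close together. Compound 3 stands within the usual scatter of the other two, as the data show with a 1.6-fold higher number from compound 1 to compound 3 (0.20 log units; within the scatter) and with a 1.3-fold higher number from compound 2 to compound 3 (0.12 log units; within the scatter) as well.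

The next compound is compound 4 `CC(C)C(c1ccc(-c2ccc3cccc(F)c3c2)[nH]c1=O)N1CCNC1=O` and it differs from compound 3 at one place. There, 2-oxoimidazolidin-1-yl comes in place of (1H-tetrazol-5-yl)methyl on a saturated chain carbon bound to an aromatic carbon and a saturated chain carbon. The counted change is 2-oxoimidazolidin-1-yl in place of (1H-tetrazol-5-yl)methyl on a saturated chain carbon bound to an aromatic carbon and a saturated chain carbon in full.

This same carbon has already carried three different groups. Besides the two steps above, the swap between the first two groups gave a 1.2-fold higher number from compound 1 to compound 2 (0.08 log units; within the scatter) and thus also stayed small. On that evidence, no step beyond the scatter is expected in this assay for the new group, in either direction. Among the measured compounds shown here, no measured compound carries a five-membered non-aromatic ring at this place, and the range below stays wide.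

The expected step is a 1.4-fold lower number from compound 3 to compound 4 (0.14 log units; within the scatter) and it remains an estimate. For compound 4 the estimated value is 20000 nM with an expected range from 9000 nM to 40000 nM in the measurement still to come.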

Compound 4, solubility: 24900 nM
For compound 4 the middle estimate is 1.2-fold (0.10 log units) below the measured one; low and high end bracket the measured number.
By their numbers in this assay, from the lowest: compounds 1, 2, 4 and 3 (each within the scatter of the next).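

Among the compounds shown here, the 2-oxoimidazolidin-1-yl group puts a five-membered non-aromatic ring on this saturated chain carbon for the first time, and in this assay the new compound stays within the scatter of all three others, with a 1.1-fold lower number from compound 3 to compound 4 (0.04 log units; within the scatter), a 1.2-fold higher number from compound 2 to compound 4 (0.08 log units; within the scatter) and a 1.4-fold higher number from compound 1 to compound 4 (0.16 log units; within the scatter). Across these four compounds, then, the ring at this place need not be aromatic for the numbers to stay this close, and the swap from compound 3 also takes the group from 4 nitrogen atoms to 2 nitrogen atoms and 1 oxygen atom, and from 3 hydrogen-bond acceptors to 1, with no step beyond the scatter. No measurement at hand explains why the values stay so close together.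

All four groups shown at this place contain a five-membered ring, so it remains open what a carboxylic acid, an open-chain amine or a plain longer carbon chain would give here. On these data alone, it also remains open whether the same closeness would hold if the isopropyl-type carbon chain or another part of the shared core were changed as well.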